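A few compounds are considered here, and "the series" means these few. Any claim that something is new, unique, unknown or untested is made for them only; others in the source may bear on it.

Among the measured compounds shown here, in an in vivo functional assay on the whole organism (MDA-MB-435 cells, Homo sapiens) for antiproliferative activity (on this read-out lower numbers stand for stronger inhibition and higher numbers for weaker inhibition), compound 1 `CO[C@@H](C(=O)NC1CC[C@@H](OC(=O)Cc2cccnc2)CNC1=O)[C@H](O)[C@@H](O)[C@H](O)/C=C/C(C)(C)C` gives 5850 nM, the higher of the two numbers measured so far, and compound 2 `CCCCCCCCCCc1ccc(C(=O)O[C@@H]2CCC(NC(=O)[C@H](OC)[C@H](O)[C@@H](O)[C@H](O)/C=C/C(C)(C)C)C(=O)NC2)cc1` gives 30 nM, well beyond the scatter. Compound 3 `CO[C@@H](C(=O)NC1CC[C@@H](OC(=O)/C=C/c2ccccc2)CNC1=O)[C@H](O)[C@@H](O)[C@H](O)/C=C/C(C)(C)C` keeps the core of compound 1, with 2-phenylethenyl in place of (pyridin-3-yl)methyl on a carbonyl carbon. For the measured compounds named here, no measured pair shows this change on its own, so compound 2 at 30 nM is the only guide, and it points toward a lower number. The expected step is a 9.8-fold lower number from compound 1 to compound 3 (0.99 log units; beyond the scatter), a drop beyond the scatter. The estimate for compound 3 is 600 nM, with an expected range of 150 nM to 2500 nM.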

Compound 3, half-maximal inhibitory concentration: 20 nM
For compound 3 the middle estimate is 30-fold (1.48 log units) above the measured one; measured number below the stated range.
By their numbers in this assay, from the lowest: compounds 3 and 2 (each within the scatter of the next); then compound 1.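

In this assay, the place on a carbonyl carbon proves highly sensitive to the group it carries: 2-phenylethenyl in place of (pyridin-3-yl)methyl gives a 290-fold lower number from compound 1 to compound 3 (2.47 log units; beyond the scatter). This single change removes the ring nitrogen and adds a double bond outside the aromatic ring. Nothing available explains the size of this step. The compounds shown leave open which of these two differences matters, as both change together. A 2-phenylethyl or a (phenyl)methyl group at the same place would separate them.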